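The source may hold more compounds than are shown below. What is called first, only, known or untested is meant among the compounds shown, and "the series" means these compounds.

Values in a functional assay on A-431 cells (Homo sapiens); a lower number here means that less compound is needed, a higher number that more compound is needed for the effect:
- Compound 1 `COc1cc(Nc2ncccc2-c2n[nH]c(Nc3ccc4c(c3)OCCO4)n2)cc(OC)c1`: 117 nM
- Compound 2 `COc1cc(OC)cc(Oc2ncccc2-c2n[nH]c(Nc3ccc4c(c3)OCCO4)n2)c1`: 3.6 nM

Compound 1 holds the higher of the two numbers. Compound 3 `COc1cc(Nc2ncccc2-c2nc(Nc3ccc4c(c3)OCCO4)n(C)n2)cc(OC)c1` keeps the core of compound 1 and carries one change: methyl in place of hydrogen on an aromatic nitrogen. Among the compounds with values here, the only measured step, a 33-fold lower number from compound 1 to compound 2 (1.51 log units; beyond the scatter), replaces (3,5-dimethoxyphenyl)amino at a different place, so it shows how far this assay can move but gives no direction for this nitrogen. A rise of smaller size than that step is expected, with low confidence. The estimated step is a 3.8-fold higher number from compound 1 to compound 3 (0.59 log units; beyond the scatter). Compound 3 is expected at 450 nM, with an estimated range of 90 nM to 3000 nM.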

Compound 3, half-maximal effective concentration: 130 nM
Beside the measured number, compound 3's estimate is 3.5-fold (0.54 log units) above it; the measured number falls inside the stated range.
By their numbers in this assay, from the lowest: compound 2; then compounds 1 and 3 (each within the scatter of the next).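

In this assay, methyl in place of hydrogen on this aromatic nitrogen gives a 1.1-fold higher number from compound 1 to compound 3 (0.05 log units; within the scatter), so this position, unlike the (3,5-dimethoxyphenyl)amino place, has not yet shown a step beyond the scatter. With the (3,5-dimethoxyphenyl)amino group in place, the hydrogen on this nitrogen can be replaced by methyl without a readable change in this assay. No supporting data bear on this result. Going by these compounds, whether an ethyl group, a longer chain or a chain ending in an amine on this nitrogen would leave the number unchanged remains open. Also open, on these data alone, is whether methyl here behaves the same alongside 3,5-dimethoxyphenoxy.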